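A few compounds are considered here, and "the series" means these few. Any claim that something is new, unique, unknown or untested is made for them only; others in the source may bear on it.

Of the compounds shown here, three have been tested so far in a functional assay on microsomes for inhibition, with a stated time of 1 h; on this read-out higher numbers stand for weaker inhibition and lower numbers for stronger inhibition. Compound 1 `COc1ccc(-c2nc(SC)n(C)c(=O)c2C#N)cc1` gives 53 ug/mL in this assay. Compound 2 `COc1ccc(-c2nc(NN)n(C)c(=O)c2C#N)cc1` shares its core with compound 1 and differs from it in one place: aminoamino in place of methylsulfanyl on an aromatic carbon. In this assay compound 2 gives 39 ug/mL, and the step from compound 1 to compound 2 is a 1.4-fold lower number from compound 1 to compound 2 (0.13 log units; within the scatter). Compound 3 `CSc1nc(-c2cccs2)c(C#N)c(=O)n1C` carries a different core, and the difference between the two cores is not broken down here. In this assay compound 3 gives 83 ug/mL; its gap to compound 1 lies within the scatter, while its gap to compound 2 lies beyond it.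

Compound 4 `Cn1c(NN)nc(-c2cccs2)c(C#N)c1=O` has not yet been measured. It stands to compound 3 as compound 2 stands to compound 1: aminoamino in place of methylsulfanyl on an aromatic carbon. The surroundings are not word for word the same, since in compound 3 the changed carbon is meta to a thiophen-2-yl group of 5 heavy atoms, whereas in compound 1 it is meta to a group of 8 heavy atoms; so this is the same kind of change, not the same change. Going by the values given here, the only guide is the earlier pair. Compound 4 is expected to show a step of a 1.4-fold lower number from compound 3 to compound 4 (0.14 log units; within the scatter) because a 1.4-fold lower number from compound 1 to compound 2 (0.13 log units; within the scatter) stayed within the scatter. The estimate for compound 4 in this assay is 60 ug/mL, with a range from 30 ug/mL to 120 ug/mL.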

Compound 4, half-maximal inhibitory concentration: 68 ug/mL
The estimate for compound 4 lay 1.1-fold (0.05 log units) below the measured number, and the stated range covers the measured number.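

In this assay, aminoamino in place of methylsulfanyl on the core carrying the thiophen-2-yl group gives a 1.2-fold lower number from compound 3 to compound 4 (0.09 log units; within the scatter), so this step cannot be told apart from the ordinary spread of repeated measurements. Set beside the earlier step, the same change looks alike on the two cores: the same change on two cores in this assay, a 1.4-fold lower number (0.13 log units; within the scatter) from compound 1 to compound 2 and a 1.2-fold lower number (0.09 log units; within the scatter) from compound 3 to compound 4, 1.1-fold (0.05 log units) apart, within the scatter of two such steps. This shows that, on these two cores, the swap leaves the read-out inside the scatter, but it does not show that aminoamino inhibits better than methylsulfanyl, and two pairs with such small steps say little about how the change would behave on any further core.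

The compounds shown leave open whether a plain amine, a longer chain such as butylsulfanyl or a ring such as morpholine on that same carbon would shift the number beyond the scatter on either core. Going by these compounds, it also remains open what a carboxylic acid in place of the cyano group would do.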